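Hydroxy to chloro on compound 2

The compounds below may be only part of what the source reports. "The series", "measured", "known", "first", "only" and "open" are said of these compounds alone.

Measured in a functional assay on HeLa cells (Homo sapiens) for inhibition, read by MTT assay, with a stated time of 72 h; a higher number here means a weaker inhibitor, a lower number a stronger inhibitor:
Compound 1 `COc1ccc(/C=C/C(=O)c2c(OC)cc(O)c(CC=C(C)C)c2O)cc1OC`: 27700 nM
Compound 2 `COc1cc(OC)c(C(=O)/C=C/c2ccc(O)cc2)c(OC)c1`: 40600 nM

With only these two measurements, compound 2 has a single neighbour, and its value lies within the usual scatter of the value of compound 1. Neither can be ranked above the other.

Compound 3 `COc1cc(OC)c(C(=O)/C=C/c2ccc(Cl)cc2)c(OC)c1` keeps the core of compound 2 and alters one group: chloro in place of hydroxy on an aromatic carbon. This puts chloro in place of hydroxy on an aromatic carbon, para to a large group, so 4-hydroxyphenyl becomes 4-chlorophenyl.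

Within the data shown here, no measured pair shows this swap, so the data offer no direct guide to its size. In this assay, a small shift towards a lower number is expected, probably not clearly beyond the scatter. The estimated change is a 1.6-fold lower number from compound 2 to compound 3 (0.21 log units; within the scatter). The estimated value for compound 3 is 25000 nM, with an expected range of 8000 nM to 70000 nM.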

Compound 3, half-maximal inhibitory concentration: 3900 nM
Compound 3: the middle estimate sits 6.4-fold (0.81 log units) above what was measured; measured number outside the range, below it.
By their numbers in this assay, from the lowest: compound 3; then compounds 1 and 2 (each within the scatter of the next).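

Compounds 1 and 2 differ in more than one place, so they could not show whether this position matters. In this assay, chloro in place of hydroxy gives a 10-fold lower number from compound 2 to compound 3 (1.02 log units; beyond the scatter), so changing one heavy atom on an aromatic carbon, para to a large group, moves the number well beyond the scatter. The swap also takes away the hydrogen-bond donor and acceptor counted for hydroxy, but no available measurement explains the drop.

Still open, going by these compounds, is whether the lower number comes from the presence of chloro or from the absence of hydroxy, a question that hydrogen, fluoro, methyl or an amine at this place could help answer. Among these compounds, with no second pair showing this swap, its size on any other core also remains unknown.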